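A few compounds are considered here, and "the series" means these few. Any claim that something is new, unique, unknown or untested is made for them only; others in the source may bear on it.

Measured compounds in an ADME assay on MT4 cells (Homo sapiens) for cytotoxicity, read by MTT assay, with a stated time of 4 days; on this read-out lower numbers stand for higher toxicity in this test and higher numbers for lower toxicity in this test:
compound 1 `N#Cc1ccc(Nc2nc(Oc3ccc(Br)cc3)c3ccccc3n2)cc1` gives 215000 nM;
compound 2 `Cc1cc(C#N)cc(C)c1Oc1nc(Nc2ccc(C#N)cc2)nc2ccccc12` gives 203000 nM;
compound 3 `N#Cc1ccc(Nc2nc(Oc3ccccc3)c3ccccc3n2)cc1` gives 370000 nM.

Compound 3 shows the highest of the three numbers, but its gaps to the others are small: a 1.7-fold higher number from compound 1 to compound 3 (0.24 log units; within the scatter) and a 1.8-fold higher number from compound 2 to compound 3 (0.26 log units; within the scatter), both within the scatter, so the three compounds cannot be ordered on this read-out.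

Compound 4 `N#Cc1ccc(Nc2nc(Oc3c(Cl)cc(Cl)cc3Cl)c3ccccc3n2)cc1` differs from compound 3 in one place: 2,4,6-trichlorophenyl in place of phenyl on an oxygen on an aromatic ring. Among the compounds with values here, the steps that bear on this change are the earlier swaps of the aryl group on the same oxygen, a 1.8-fold higher number from compound 2 to compound 3 (0.26 log units; within the scatter) and a 1.1-fold lower number from compound 1 to compound 2 (0.02 log units; within the scatter), and the removal of a halogen from that aryl group, a 1.7-fold higher number from compound 1 to compound 3 (0.24 log units; within the scatter). None of these moved the number beyond the scatter, whether the aryl carried a halogen, a nitrile with two methyl groups, or nothing. Within the data shown here, no step with three chlorines on that ring has been measured, so the change is larger than any seen, but nothing in the measured set points to a direction.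

The expectation for compound 4 is therefore no step beyond the scatter, a 1.4-fold lower number from compound 3 to compound 4 (0.15 log units; within the scatter), with the number placed between the values of compound 3 and compound 1. Compound 4 is estimated at 260000 nM, within a range from 110000 nM to 550000 nM.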

Compound 4, half-maximal cytotoxic concentration: 56000 nM
For compound 4 the middle estimate is 4.6-fold (0.67 log units) above the measured one; the whole stated range lies above it.
By their numbers in this assay, from the lowest: compound 4; then compounds 2, 1 and 3 (each within the scatter of the next).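

In this assay the aryl group on the oxygen proves able to shift the number: a 6.6-fold lower number from compound 3 to compound 4 (0.82 log units; beyond the scatter) is a step beyond the scatter, whereas the earlier swaps at this position all stayed within it. The change also separates 2,4,6-trichlorophenyl from the two other substituted aryl groups, with a 3.6-fold lower number from compound 2 to compound 4 (0.56 log units; beyond the scatter) and with a 3.8-fold lower number from compound 1 to compound 4 (0.58 log units; beyond the scatter) as well, so compound 4 has the lowest number of the four and lies beyond the scatter from each of the others, while 4-bromophenyl, 4-cyano-2,6-dimethylphenyl and phenyl remain unresolved from one another. Nothing measured here accounts for this higher toxicity in the test.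

From the compounds shown here alone, whether one or two chlorines on that ring would already lower the number, and whether an amine or a carboxylic acid on the ring would act in the same direction, remains open. Also open, going by these compounds, is whether a longer alkyl chain on the oxygen, in place of the aryl group, would keep the number near that of compound 3 or move it as far as the 2,4,6-trichlorophenyl group does.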